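Cytotoxicity notes on a diarylamine series

The compounds below may be only part of what the source reports. "The series", "measured", "known", "first", "only" and "open" are said of these compounds alone.

Two compounds have been run in an ADME assay on PBMC cells (Homo sapiens) for cytotoxicity, read by MTT assay, with a stated time of 72 h, in the absence of a further agent; a higher number here means a weaker inhibitor, a lower number a stronger inhibitor. Compound 1 `COc1ccc(Nc2cccnc2)cc1` gives 96000 nM, and compound 2 `COc1ccc(Nc2nc3ccccc3cc2-c2ccc(C)cc2)cc1` gives 137000 nM; the two numbers lie within the usual scatter of each other, so compound 2 stands indistinguishable from compound 1. Compound 3 `COc1ccc(Nc2ccc3ccccc3n2)cc1` is the next entry. Relative to compound 2 it carries the change (hydrogen in place of 4-methylphenyl on an aromatic carbon). Among the measured compounds shown here, with only two weakly toxic compounds at hand, no step beyond the scatter is expected in this assay; the step from compound 2 to compound 3 is estimated as a 1.1-fold lower number from compound 2 to compound 3 (0.06 log units; within the scatter). For compound 3 the expected value is 120000 nM, with a range of 50000 nM to 300000 nM.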

Compound 3, half-maximal inhibitory concentration: 91000 nM
Estimate against measurement, compound 3: 1.3-fold (0.12 log units) above; the range from low to high includes it.
By their numbers in this assay, from the lowest: compounds 3, 1 and 2 (each within the scatter of the next).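

In this assay, hydrogen in place of 4-methylphenyl on the aromatic carbon two atoms from the ring nitrogen gives a step within the scatter (a 1.5-fold lower number from compound 2 to compound 3 (0.18 log units; within the scatter)). At this position, therefore, the two substituents cannot be told apart in this read-out, and the 4-methylphenyl group is not needed for the weak cytotoxicity seen with compound 3. No measurement on hand bears on why this is so. Going by these compounds, whether an amine, a carboxylic acid or a longer chain at this carbon would produce a step beyond the scatter remains open.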